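The source may hold more compounds than are shown below. What is called first, only, known or untested is meant among the compounds shown, and "the series" means these compounds.

Measured so far:
compound 1 `COc1cc(Cl)cc(-c2nn(-c3cccc(NC(=O)Nc4cccc(C(F)(F)F)c4)c3)cc2-c2ccncc2)c1`: 97%
compound 2 `COc1cc(Cl)cc(-c2nn(-c3cccc(NC(=O)Nc4ccc(Cl)c(Cl)c4)c3)cc2-c2ccncc2)c1`: 96%

In a functional assay on KM12 cells (Homo sapiens) for inhibition, read by sulforhodamine B assay, with a stated time of 48 h, tested at 0.01 uM (a higher number here means a weaker effect of the compound at the concentration tested, a lower number a stronger effect), compound 1 gives 97%, the highest of the two numbers, and compound 2 gives 96%. Within the data shown here, the only step between them, a number 1 percentage points lower from compound 1 to compound 2 (within the scatter), lies within the scatter, so both compounds show only a weak effect at the concentration used and cannot be ordered against each other.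

Compound 3 `COc1cc(Cl)cc(-c2nn(-c3cccc(NC(=O)Nc4cc(C(F)(F)F)cc(C(F)(F)F)c4)c3)cc2-c2ccncc2)c1` differs from compound 1 by trifluoromethyl in place of hydrogen on an aromatic carbon. Among the measured compounds shown here, no measured step exchanges hydrogen for trifluoromethyl; the one step available in this assay, a number 1 percentage points lower from compound 1 to compound 2 (within the scatter), exchanges one aryl group on the amide-type nitrogen for another and moves nothing beyond the scatter. Both measured compounds sit near the top of the scale, which leaves little room for a higher number. On this basis no step beyond the scatter is expected for compound 3, and compound 3 is estimated at 95% (range 82% to 103%), a step of a number 2 percentage points lower from compound 1 to compound 3 (within the scatter).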

Compound 3, a percentage reported as activity, at one concentration (the size of the read-out at that concentration, not a potency): 97%
The estimate for compound 3 lay 2 percentage points below the measured number; the measured number falls inside the stated range.
By their numbers in this assay, from the lowest: compounds 2, 1 and 3 (each within the scatter of the next).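

In this assay, trifluoromethyl in place of hydrogen on this aromatic carbon, meta to a trifluoromethyl group, gives no change at the digits printed from compound 1 to compound 3 (within the scatter). The earlier step exchanged one aryl group for another, whereas this one adds 4 heavy atoms to the ring of compound 1 and still leaves the number within the scatter, so this position shows no response to the added bulk at the concentration tested. That reading is limited, since a number this close to the top of the scale cannot separate a position without influence from a compound that is simply too dilute to act, and nothing available bears on the reason for the flat result.

From the compounds shown here alone, whether an amine or a carboxylic acid on this same aromatic carbon would move the number beyond the scatter stays open. Also open, going by these compounds, is whether compound 1 and compound 3 would still match at a higher concentration, where the read-out would have room to separate them.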